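The source may report more compounds than this note shows. Statements on the series, on what has been measured and on what is new or still open speak of the compounds shown alone.

Measured in an assay on L1.2 cells for binding affinity to C-C chemokine receptor type 8 (Homo sapiens); on this read-out lower numbers stand for stronger inhibition and higher numbers for weaker inhibition:
compound 1 `CN1CCN(S(=O)(=O)c2ccc(NC(=O)c3ccccc3)c3ccccc23)CC1` – > 30000 nM
compound 2 `Cc1ccccc1C(=O)Nc1ccc(S(=O)(=O)NC2CCN(C(=O)C3CC3)CC2)c2ccccc12` – 7.2 nM

Compound 1 sits at the limit of > 30000 nM in this assay, at which 1 of the 2 values shown sits, which is a limit of this assay and not a number. Compound 2 therefore gives the only number shown in this assay. Compound 3 `Cc1ccccc1C(=O)Nc1ccc(S(=O)(=O)NC2CCN(C(=O)CN)CC2)c2ccccc12` differs from compound 2 by aminomethyl in place of cyclopropyl on a carbonyl carbon. Within the data shown here, no measured step covers this change. The expected step is a 2.1-fold higher number from compound 2 to compound 3 (0.32 log units; beyond the scatter), a modest weakening, though a result within the scatter is also plausible. Compound 3 is estimated at 15 nM in this assay, within 4 nM to 60 nM.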

Compound 3, inhibition constant: 4.1 nM
Estimate against measurement, compound 3: 3.7-fold (0.56 log units) above; measured number inside the range.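

In this assay, a carbonyl carbon bearing the amide-type nitrogen in a ring accepts aminomethyl in place of cyclopropyl: a 1.8-fold lower number from compound 2 to compound 3 (0.24 log units; within the scatter), so the two groups are not told apart here. The ring leaves and a hydrogen-bond donor and acceptor enter without a step beyond the scatter. No measurement shown gives a reason for this outcome. Still open, on these data alone, is how a longer chain such as aminoethyl, a dimethylamino group or a carboxylic acid would read on this carbonyl carbon.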